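Replacing 2-aminophenyl with 4-nitrophenyl on compound 2

This account rests on a few compounds, and the source may have more. Where it says the series, first, only, none or still open, it means among the compounds named here.

In a functional assay on SK-OV-3 cells (Homo sapiens) for inhibition, read by CCK-8 assay, with a stated time of 70 h (on this read-out lower numbers stand for stronger inhibition and higher numbers for weaker inhibition), compound 1 (`c1ccc(COc2ccc(OCCOCCNC3CCCCC3)cc2)cc1`) gives 7370 nM, compound 2 (`Nc1ccccc1COc1ccc(OCCOCCNC2CCCC2)cc1`) gives 14000 nM and compound 3 (`CC(C)(C)OC(=O)n1ccc(NCCOCCOc2ccc(OCc3ccccc3)cc2)c1`) gives 13000 nM. Compound 2 therefore stands level with the other two, since its number lies within the scatter of both compound 3 and compound 1. Going by the values given here, no two measured compounds differ in only one place, so no single structural change has yet been measured on its own.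

Compound 4 (`O=[N+]([O-])c1ccc(COc2ccc(OCCOCCNC3CCCC3)cc2)cc1`) departs from compound 2 on a saturated chain carbon bound to an oxygen on an aromatic ring: 4-nitrophenyl in place of 2-aminophenyl on a saturated chain carbon bound to an oxygen on an aromatic ring. The closeness of the three measured numbers gives no ground for a direction, and no step beyond the scatter is expected in this assay. The expected change, a 1.6-fold lower number from compound 2 to compound 4 (0.19 log units; within the scatter), is correspondingly modest. For compound 4, the estimated value is 9000 nM, with an expected range from 4000 nM to 20000 nM.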

Compound 4, half-maximal inhibitory concentration: 20300 nM
Estimate against measurement, compound 4: 2.3-fold (0.35 log units) below, and the stated range ends below it.
By their numbers in this assay, from the lowest: compounds 1, 3, 2 and 4 (each within the scatter of the next, the first and the last beyond it).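

In this assay the exchange of 2-aminophenyl for 4-nitrophenyl on a saturated chain carbon bound to an oxygen on an aromatic ring gives a 1.5-fold higher number from compound 2 to compound 4 (0.16 log units; within the scatter) and so leaves the two compounds level. Going by these compounds alone, this is the first change measured on its own, and although it takes away the hydrogen-bond donor counted on the group and brings in a double bond outside aromatic rings, the read-out does not separate compound 2 from compound 4. No measured information ties this outcome to any feature of either group.

Within the data shown here, whether 4-aminophenyl or 2-nitrophenyl would read differently at this place remains open, since the single step alters both the substituent and its printed ring number. Also open, as far as these compounds go, is whether a carboxylic acid on this ring would move the number beyond the scatter.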